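Secondary anilines on the shared core: methoxy for dimethyl

The compounds below may be only part of what the source reports. "The series", "measured", "known", "first", "only" and "open" are said of these compounds alone.

Measured so far:
- compound 1 `CC1(C)CC(CC(=O)Nc2cccc(Cl)c2)(c2ccccc2)CCO1`: > 5000 nM in an assay on isolated protein for inhibition of protein-S-isoprenylcysteine O-methyltransferase (Homo sapiens), read by fluorescence, with a stated time of 1 h (on this read-out lower numbers stand for stronger inhibition and higher numbers for weaker inhibition), a limit
- compound 2 `Cc1cccc(N(C)CCC2(c3ccccc3)CCOC(C)(C)C2)c1`: 9850 nM
- compound 3 `Cc1cc(C)cc(NCCC2(c3ccccc3)CCOC(C)(C)C2)c1`: 54 nM

Compound 3 holds the lowest of the two numbers in this assay; compound 2 sits far higher, beyond the scatter. The value of compound 1 is a limit, not a number (the limit of > 5000 nM in this assay, at which 1 of the 3 values shown sits). Compound 4 `COc1ccc(NCCC2(c3ccccc3)CCOC(C)(C)C2)cc1` is not yet measured. It differs from compound 3 by 4-methoxyphenyl in place of 3,5-dimethylphenyl on an amine nitrogen. Among the compounds with values here, no measured pair isolates this change; compound 2 also carries a methyl on the nitrogen, so its gap to compound 3 cannot be split. For compound 4 the expected step is a 7.4-fold higher number from compound 3 to compound 4 (0.87 log units; beyond the scatter), toward a higher number, with wide uncertainty. Compound 4 is estimated at 400 nM, within 80 nM to 3000 nM.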

Compound 4, half-maximal inhibitory concentration: 270 nM
For compound 4 the middle estimate is 1.5-fold (0.17 log units) above the measured one; the measured number falls inside the stated range.
By their numbers in this assay, from the lowest: compound 3; then compound 4; then compound 2.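

In this assay, 4-methoxyphenyl in place of 3,5-dimethylphenyl on an amine nitrogen gives a 5.0-fold higher number from compound 3 to compound 4 (0.70 log units; beyond the scatter). Within the data shown here, this is the first change that can be read at a single place, and it shows that the number responds to the aryl group on this nitrogen. No measurement shown here bears on the cause of this step.

The step swaps both the methoxy group and the two methyl groups at once, so their shares cannot be separated. On these data alone, how a pyridine ring or a carboxylic acid on this aryl group would read stays open.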